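The compounds below may be only part of what the source reports. "The series", "measured", "known", "first", "only" and "open" are said of these compounds alone.

Measured in a functional assay on B16-F0 cells (Mus musculus) for inhibition, read by CCK-8 assay, with a stated time of 48 h; on this read-out higher numbers stand for weaker inhibition and lower numbers for stronger inhibition:
- compound 1 `COc1cc(-c2ccnc3cc(-c4c[nH]c5ccccc45)nn23)cc(OC)c1OC`: 40 nM
- compound 2 `COc1cc(-c2ccnc3cc(-c4ccc(C)c(C)c4)nn23)cc(OC)c1OC`: 391 nM

Compound 2, at 391 nM, holds the higher of the two numbers and is the weaker inhibitor of the pair. Compound 3 `COc1cc(-c2ccnc3cc(-c4cccc(C#N)c4)nn23)cc(OC)c1OC` keeps the shared core and changes the same place: 3-cyanophenyl in place of 3,4-dimethylphenyl on an aromatic carbon. Within the data shown here, only one measured step bears on this place: a 9.8-fold higher number from compound 1 to compound 2 (0.99 log units; beyond the scatter), with 3,4-dimethylphenyl replacing 1H-indol-3-yl. That step lies beyond the scatter, but it replaced a different group. The present exchange keeps one six-membered aromatic ring of carbon only on both sides, so a smaller step is expected in this assay. The data support no direction for it. The expected change is a 1.2-fold higher number from compound 2 to compound 3 (0.06 log units; within the scatter), probably within the scatter. For compound 3 the estimated value is 450 nM, with an expected range of 130 nM to 1500 nM.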

Compound 3, half-maximal inhibitory concentration: > 10000 nM
Compound 3: only a limit was reported (the forecaster's own chance of this, stated with the estimate: 5%); middle value at least 22-fold (1.34 log units) away from the limit.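

In this assay, the step of an at least 25-fold higher number from compound 2 to compound 3 (1.40 log units; beyond the scatter) shows that this position does not accept every six-membered aromatic ring of carbon only: the ring type and the heavy-atom count stay the same, and the exchange of 3,4-dimethylphenyl for 3-cyanophenyl alone carries the loss. Measured against the 1H-indol-3-yl group, the exchange gives an at least 250-fold higher number from compound 1 to compound 3 (2.39 log units; beyond the scatter), so the substituents on the ring at this place can matter as much as the choice of ring. The value of compound 3 is a limit of the assay and not a number: the limit of > 10000 nM in this assay, at which 1 of the 3 values shown sits.

As far as these compounds go, whether the loss follows the entering nitrile or the departing methyl groups remains open, as compound 2 and compound 3 differ in both. Plain phenyl, 3-methylphenyl, or a phenyl ring carrying an amine or a carboxylic acid would help separate these two readings.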